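The source may hold more compounds than are shown below. What is called first, only, known or untested is meant among the compounds shown, and "the series" means these compounds.

Working notes on the series, read in an ADME assay on MT4 cells (Homo sapiens) for cytotoxicity, read by MTT assay; on this read-out higher numbers stand for lower toxicity in this test and lower numbers for higher toxicity in this test. Compound 1 `Cc1ccc(CC2C(=O)N(O)C(=O)c3ccccc32)cc1` gives 5500 nM and compound 2 `CCCCCCC1C(=O)N(O)C(=O)c2ccccc21` gives 4400 nM. These two stand level, with a 1.3-fold lower number from compound 1 to compound 2 (0.10 log units; within the scatter). Compound 3 `CCCCC1C(=O)N(O)C(=O)c2ccccc21` gives 25400 nM, the highest number of the three.

The open case is compound 4 `CCC1C(=O)N(O)C(=O)c2ccccc21`, with methyl in place of 4-methylphenyl on a saturated chain carbon bound to a saturated ring carbon.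

For the measured compounds named here, two measured steps bear most directly on it. The nearest change, propyl in place of 4-methylphenyl at the same place, gave a 4.6-fold higher number from compound 1 to compound 3 (0.66 log units; beyond the scatter), a modest rise. Shortening the chain alone gave a 5.8-fold higher number from compound 2 to compound 3 (0.76 log units; beyond the scatter), also modest and in the same direction. Pentyl at that place, in compound 2, showed no change beyond the scatter from compound 1, so the rise appears only with the shorter chain of compound 3. This rests on very few compounds, and no chain shorter than propyl at that place has been measured yet.

A rise of similar or somewhat larger size than that seen for compound 3 is therefore expected. The estimated step is a 7.6-fold higher number from compound 1 to compound 4 (0.88 log units; beyond the scatter). For compound 4 the estimated value is 42000 nM, with an expected range of 18000 nM to 100000 nM.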

Compound 4, half-maximal cytotoxic concentration: 250000 nM
Compound 4: the middle estimate sits 6.0-fold (0.77 log units) below what was measured; the measured number lies above the stated range.
By their numbers in this assay, from the lowest: compounds 2 and 1 (each within the scatter of the next); then compound 3; then compound 4.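

In this assay the rise that first appeared with propyl does not stop there: methyl carries it further in the same direction, with a 9.8-fold higher number from compound 3 to compound 4 (0.99 log units; beyond the scatter), so the number goes up at each shortening from compound 2 through compound 3 to compound 4. Over the full span of chain lengths the change at this place is large, with a 57-fold higher number from compound 2 to compound 4 (1.75 log units; beyond the scatter) and a 45-fold higher number from compound 1 to compound 4 (1.66 log units; beyond the scatter), so 4-methylphenyl and pentyl, which stood level, both lie far from methyl, a gap of a size that no earlier step had shown. No measurement at hand offers an explanation for this climb in the number with the smallest group.

On these data alone, it remains open whether hydrogen or ethyl at this place would fit the same run of numbers, and whether a longer chain such as octyl would stay level with compound 2 or fall lower. Also open, as far as these compounds go, is whether a short chain bearing an amine or a carboxylic acid would sit with compound 4 or with compound 1, and whether phenyl without its methyl would stand level with compound 1.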